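Removing the guanidine-bearing side chain from compound 1

A few compounds are considered here, and "the series" means these few. Any claim that something is new, unique, unknown or untested is made for them only; others in the source may bear on it.

Compound 1 `N=C(N)NCCC[C@H](NC(=O)CN(c1nc(Cl)nc2[nH]cnc12)C1CC1)C(=O)O`: 51%
Compound 2 `N=C(N)NCCC[C@H](NC(=O)CN(c1nc(Cl)nc2[nH]cnc12)C1CC1)C(=O)OCc1ccccc1`: 30.6%
Compound 3 `O=C(OCc1ccccc1)[C@@H]1CCCN1C(=O)CN(c1ncnc2c1ncn2C1CCCCO1)C1CC1`: 36.7%

Of the compounds shown here, three have been tested in a functional assay on the whole organism (Tail, strain ICR) with Mus musculus as the target, in the tail flick test, with a stated time of 60 min, at a dose of 25 umol/kg by the oral route; on this read-out lower numbers stand for a weaker effect and higher numbers for a stronger effect at the one dose given. Compound 1 gives 51% and stands highest of the three; compound 3 comes nearest with 36.7%, and compound 2 is furthest with 30.6%, both gaps lying beyond the scatter. Going by the values given here, the only step between two compounds that differ in a single place is a number 20.4 percentage points lower from compound 1 to compound 2 (beyond the scatter), and it concerns the oxygen of the acid group, not the side chain.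

Compound 4 `O=C(O)CNC(=O)CN(c1nc(Cl)nc2[nH]cnc12)C1CC1` has not yet been measured. It arises from compound 1 by the change (a hydrogen atom in place of a group of 7 heavy atoms (4 carbon, 3 nitrogen; no ring), on a saturated chain carbon bound to an amide-type nitrogen and a carbonyl carbon). Here the acid group of compound 1 is kept, while the long chain carrying the guanidine is stripped away and only a hydrogen atom remains. Among the compounds with values here, no measured step touches this chain, so the step from compound 1 to compound 4 in this assay cannot be read off directly; the one step known, a number 20.4 percentage points lower from compound 1 to compound 2 (beyond the scatter), shows only that changing the end of compound 1 can lower the read-out.

With that in mind, compound 4 is expected to come out at 30%, within a range from 10% to 50%, which would mean an estimated step of a number 21 percentage points lower from compound 1 to compound 4 (beyond the scatter) from compound 1.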

Compound 4, a percentage reported as activity, at one dose (the size of the read-out at that dose, not a potency): 38.9%
For compound 4 the middle estimate is 8.9 percentage points below the measured one, and the stated range covers the measured number.
By their numbers in this assay, from the lowest: compounds 2, 3 and 4 (each within the scatter of the next); then compound 1.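

In this assay, going by these compounds alone, this is the first change at the saturated chain carbon bound to an amide-type nitrogen and a carbonyl carbon, and putting a hydrogen atom in place of the group of 7 heavy atoms gives a number 12.1 percentage points lower from compound 1 to compound 4 (beyond the scatter) so the chain carrying the guanidine matters for the read-out at this dose. The effect does not vanish, however, as compound 4 still gives 38.9% in this whole-animal test, so the chain does not account for the entire response. The acid group is the same in both compounds, which ties this step to the chain alone, whereas the earlier step of a number 20.4 percentage points lower from compound 1 to compound 2 (beyond the scatter) arose at the acid oxygen, so a change at either of these two places in compound 1 lowers the number.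

Only the two extremes at this place are shown, the full chain and a bare hydrogen atom, so it remains open whether a methyl group, a shorter carbon chain or a chain ending in an amine would keep the read-out of compound 1. The data shown offer no measured explanation for why removing the chain has this effect.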